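Anilino in place of piperidin-1-yl on compound 3

The source may report more compounds than this note shows. Statements on the series, on what has been measured and on what is new or still open speak of the compounds shown alone.

Going by the values given here, in a functional assay on the whole organism with Mus musculus as the target (on this read-out higher numbers stand for an effect only at larger amounts of compound and lower numbers for an effect already at smaller amounts), compound 1 `CCCSCC1(C)Cc2c(C)c(N)c(C)c(C)c2O1` gives 24.6 mg/kg, and compound 3 `Cc1c(C)c2c(c(C)c1N)CC(C)(CN1CCCCC1)O2` gives 11.7 mg/kg, the lowest number so far. Compound 2 `Cc1c(C)c2c(c(C)c1N)CC(C)(CSCCO)O2` gives > 50 mg/kg, which is a limit of the assay and not a number. Compound 4 `Cc1c(C)c2c(c(C)c1N)CC(C)(CNc1ccccc1)O2` carries anilino in place of piperidin-1-yl on a saturated chain carbon bound to a saturated ring carbon. Among the compounds with values here, no measured step makes this exact exchange, but two changed the same place: a 2.1-fold lower number from compound 1 to compound 3 (0.32 log units; beyond the scatter) and an at least 4.2-fold lower number from compound 2 to compound 3 (0.63 log units; beyond the scatter). Neither involves anilino, so they suggest only a rough size. With compound 3 at the low end at 11.7 mg/kg, a modest rise is expected, namely a 2.1-fold higher number from compound 3 to compound 4 (0.33 log units; beyond the scatter). For compound 4 the estimated value is 25 mg/kg, with an expected range of 9 mg/kg to 50 mg/kg.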

Compound 4, dose for 50% inhibition: 15.7 mg/kg
Estimate against measurement, compound 4: 1.6-fold (0.20 log units) above, and the stated range covers the measured number.
By their numbers in this assay, from the lowest: compounds 3, 4 and 1 (each within the scatter of the next, the first and the last beyond it). At a limit, above all of these: compound 2.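

In this assay, anilino and piperidin-1-yl on this saturated chain carbon cannot be told apart (a 1.3-fold higher number from compound 3 to compound 4 (0.13 log units; within the scatter)), so this position accepts an aromatic ring as well as a non-aromatic one. Anilino and propylsulfanyl also stay within the scatter of each other (a 1.6-fold lower number from compound 1 to compound 4 (0.20 log units; within the scatter)). The value of compound 2 is a limit of the assay and not a number, so the step to anilino is only a floor (an at least 3.1-fold lower number from compound 2 to compound 4 (0.50 log units; beyond the scatter)). From the compounds shown here alone, it remains open whether morpholin-4-yl in place of piperidin-1-yl, or a fluorine on the anilino ring, would keep the number in this range.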